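Phenyl in Place of Amino on a Fused Dioxane Core

The source may hold more compounds than are shown below. What is called first, only, known or untested is meant among the compounds shown, and "the series" means these compounds.

Compound 2 `CN1CCC[C@H]1[C@H]1COc2cc(N)ccc2O1` was tested in an assay on membranes from Cerebral cortex for displacement of a labelled ligand from Neuronal acetylcholine receptor; alpha4/beta2 (Rattus norvegicus), with a stated time of 5 min (on this read-out higher numbers stand for weaker inhibition and lower numbers for stronger inhibition), where compound 2 gives 74000 nM. Its stereoisomer compound 1 `CN1CCC[C@H]1[C@@H]1COc2cc(N)ccc2O1` has the same atoms and bonds and differs only in the configuration as drawn; in this assay compound 1 gives 86000 nM. The step of a 1.2-fold lower number from compound 1 to compound 2 (0.07 log units; within the scatter) lies within the scatter, so the two numbers cannot be told apart, and compound 2 stands level with compound 1.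

Compound 3 `CN1CCC[C@H]1[C@H]1COc2cc(-c3ccccc3)ccc2O1` has not been measured. It differs from compound 2 by phenyl in place of amino on an aromatic carbon. Among the compounds with values here, the only measured step, a 1.2-fold lower number from compound 1 to compound 2 (0.07 log units; within the scatter), turns on a stereocentre and not on the substituent of the aromatic ring (the fact that compounds 1 and 2 differ only in the configuration as drawn), so it offers no guidance on the size or direction of the change from amino to phenyl. With nothing bearing on the change, no step beyond the scatter in this assay is expected in either direction, but the uncertainty is wide, and a number this high may come back only as a limit. For compound 3 the expected value in this assay is 60000 nM, with a range from 10000 nM to 300000 nM, corresponding to the expected step of a 1.2-fold lower number from compound 2 to compound 3 (0.09 log units; within the scatter).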

Compound 3, inhibition constant: 92000 nM
Beside the measured number, compound 3's estimate is 1.5-fold (0.19 log units) below it; measured number inside the range.
By their numbers in this assay, from the lowest: compounds 2, 1 and 3 (each within the scatter of the next).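

Phenyl in place of amino on this aromatic carbon, meta to a fused ring and para to a fused ring, gives a 1.2-fold higher number from compound 2 to compound 3 (0.09 log units; within the scatter) in this assay, so the two numbers cannot be told apart. Within the data shown here, this is the first reading on the substituent at this position rather than on configuration: a group with more heavy atoms and a ring of its own, and with no hydrogen-bond donor or acceptor, takes the place of amino, and compound 3 at 92000 nM stands level with compound 2 at 74000 nM. No fact to hand bears on why the exchange of amino for phenyl leaves the number where it stands.

As far as these compounds go, what stays open is whether any other group on this aromatic carbon, such as hydroxyl, a carboxylic acid or chloro, would move the number beyond the scatter from that of compound 2. Also open, from the compounds shown here alone, is whether phenyl in place of amino would read the same way on compound 1, the stereoisomer of compound 2.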